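Same terminal change carried onto a second core

The source may hold more compounds than are shown below. What is called first, only, known or untested is meant among the compounds shown, and "the series" means these compounds.

Compound 3 `CC(C)c1ccc(Oc2ccc(O)c(O)c2)c(-c2ccsc2S(=O)(=O)NCCNC(=O)Nc2cc(Cl)cc(Cl)c2)c1` gives 6500 nM in a functional assay on HL-60 cells (Homo sapiens) for inhibition, read by CCK-8 assay, with a stated time of 48 h; a lower number here means a stronger inhibitor, a higher number a weaker inhibitor. Compound 1 `CC(C)c1ccc(Oc2ccc(O)c(O)c2)c(-c2ccsc2S(=O)(=O)NCCNC(=S)Nc2ccc([N+](=O)[O-])cc2)c1` gives 8800 nM. The change a group of 12 heavy atoms (7 carbon, 2 nitrogen, 2 oxygen, 1 sulfur; one six-membered aromatic ring of carbon only) in place of a group of 11 heavy atoms (7 carbon, 1 nitrogen, 1 oxygen, 2 chlorine; one six-membered aromatic ring of carbon only), on an amine nitrogen produced the step of a 1.4-fold higher number from compound 3 to compound 1 (0.13 log units; within the scatter). Compound 2 `O=C(NCCNS(=O)(=O)c1ccc(-c2ccccc2O[C@H]2CC[C@H](O)CC2)s1)Nc1cc(Cl)cc(Cl)c1` rests on another core; how the core of compound 2 differs from that of compound 3 is not broken down here. In this assay compound 2 is reported only as a limit, > 20000 nM, recorded as the limit of > 20000 nM in this assay, at which 1 of the 3 values shown sits. Compound 4 `O=[N+]([O-])c1ccc(NC(=S)NCCNS(=O)(=O)c2ccc(-c3ccccc3O[C@H]3CC[C@H](O)CC3)s2)cc1` carries the same change, (a group of 12 heavy atoms (7 carbon, 2 nitrogen, 2 oxygen, 1 sulfur; one six-membered aromatic ring of carbon only) in place of a group of 11 heavy atoms (7 carbon, 1 nitrogen, 1 oxygen, 2 chlorine; one six-membered aromatic ring of carbon only), on an amine nitrogen), onto the core of compound 2, at the same place. This expectation rests on compound 3, where the change gave a 1.4-fold higher number from compound 3 to compound 1 (0.13 log units; within the scatter). Compound 4 is therefore expected near 25000 nM, between 8000 nM and 60000 nM, a step that the limit leaves unreadable from compound 2 to compound 4, and most likely to be reported again only as a limit.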

Compound 4, half-maximal inhibitory concentration: 11600 nM
Beside the measured number, compound 4's estimate is 2.2-fold (0.33 log units) above it; the range from low to high includes it.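

Compound 2 is recorded in this assay only as a limit, > 20000 nM. On these data alone, on this core, the change gives an at least 1.7-fold lower number from compound 2 to compound 4 (0.23 log units; that floor lies within the scatter); this figure is only a floor, so the true size of the step remains unknown. Whether the change behaves alike on the two cores cannot be settled: the same change on two cores in this assay, a 1.4-fold higher number (0.13 log units; within the scatter) from compound 3 to compound 1 and an at least 1.7-fold lower number (0.23 log units; that floor lies within the scatter) from compound 2 to compound 4; the limit leaves it open whether they differ

The change replaces the carbonyl with a thiocarbonyl and the two chlorines with a nitro group together, and the compounds shown do not separate these two parts. Also open, as far as these compounds go, is how an amine or a carboxylic acid on that aromatic ring, or a longer chain on the amine nitrogen, would read on either core.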